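Returning a Sulfanyl Group in Place of the Methoxypyrrolidine

The source may report more compounds than this note shows. Statements on the series, on what has been measured and on what is new or still open speak of the compounds shown alone.

In an ADME assay on the whole organism (Rattus norvegicus, strain Sprague-Dawley) for pharmacokinetics, read by LC-MS, with stated times of 5 min and 24 h, at a dose of 5 mg/kg by the oral route (a higher number here means more compound in the circulation at the dose given, a lower number less compound in the circulation), compound 1 `N#Cc1cnc(NC(=O)N2CCCc3cc(CN4CCOCC4=O)c(C=O)nc32)cc1S[C@H]1CCOC1` gives 1950 ng.h/mL, whereas compound 2 `CO[C@H]1CCN(c2cc(NC(=O)N3CCCc4cc(CN5CCOCC5=O)c(C=O)nc43)ncc2C#N)C1` gives 14700 ng.h/mL, the higher of the two numbers available. The step between them, a 7.5-fold higher number from compound 1 to compound 2 (0.88 log units; beyond the scatter), lies beyond the scatter and accompanies 3-methoxypyrrolidin-1-yl in place of (oxolan-3-yl)sulfanyl on an aromatic carbon.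

Compound 3 `N#Cc1cnc(NC(=O)N2CCCc3cc(CN4CCOCC4=O)c(C=O)nc32)cc1S[C@@H]1CCOC1` has yet to be measured. It departs from compound 2 through (oxolan-3-yl)sulfanyl in place of 3-methoxypyrrolidin-1-yl on an aromatic carbon, ortho to a cyano group and opposite the ring nitrogen: (oxolan-3-yl)sulfanyl in place of 3-methoxypyrrolidin-1-yl on an aromatic carbon. For the measured compounds named here, this reverses the one measured step, except that the defined stereocentre of the entering group is the opposite of that in compound 1. The data hold no measurement of what that difference does, so the range must stay wide.

Going by the values given here, the only guide is a 7.5-fold higher number from compound 1 to compound 2 (0.88 log units; beyond the scatter), which suggests a fall of similar size in this assay, beyond the scatter. The expected step is a 5.9-fold lower number from compound 2 to compound 3 (0.77 log units; beyond the scatter). Compound 3 is estimated at 2500 ng.h/mL, with an expected range of 800 ng.h/mL to 7500 ng.h/mL.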

Compound 3, area under the concentration-time curve: 6780 ng.h/mL
Compound 3: the middle estimate sits 2.7-fold (0.43 log units) below what was measured, within the range that was stated.
By their numbers in this assay, from the lowest: compound 1; then compound 3; then compound 2.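

The (oxolan-3-yl)sulfanyl group on this aromatic carbon, ortho to a cyano group and opposite the ring nitrogen, does not have a single standing against 3-methoxypyrrolidin-1-yl in this assay. With the other configuration, exchanging the two groups gives a 2.2-fold lower number from compound 2 to compound 3 (0.34 log units; beyond the scatter), and the methoxypyrrolidine still keeps the higher number, so the order of the two groups holds for both forms of the sulfanyl group. Configuration at the saturated ring carbon is itself a variable here, with a 3.5-fold higher number from compound 1 to compound 3 (0.54 log units; beyond the scatter), and this step can be assigned to that stereocentre alone because nothing else separates the pair: the fact that compounds 1 and 3 differ only in the configuration as drawn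

The compounds shown leave open whether inverting the stereocentre of 3-methoxypyrrolidin-1-yl would shift the number in the same way, and whether these differences in the circulation arise from uptake or from removal of the compound. They also do not show what a simple open-chain amine such as dimethylamino, or a methylsulfanyl group with no ring at all, would give on this same aromatic carbon.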